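A few compounds are considered here, and "the series" means these few. Any claim that something is new, unique, unknown or untested is made for them only; others in the source may bear on it.

Measured so far:
compound 1 `COc1cc(C2=NN(C(C)=O)C(c3cccc(OC)c3OC)O2)cc(OC)c1OC` — 35%
compound 2 `COc1ccc(C2OC(c3cc(OC)c(OC)c(OC)c3)=NN2C(C)=O)c(OC)c1` — 69.5%
compound 3 `COc1cc(C2=NN(C(C)=O)C(c3ccccc3C(F)(F)F)O2)cc(OC)c1OC` — -11%

In a functional assay on PC-3 cells (Homo sapiens) for antiproliferative activity, read by MTT assay, tested at 1 uM (a higher number here means a stronger effect of the compound at the concentration tested, a lower number a weaker effect), compound 3 stands lowest of the three; the nearest step into it is a number 46 percentage points lower from compound 1 to compound 3 (beyond the scatter), and the widest step into it is a number 80.5 percentage points lower from compound 2 to compound 3 (beyond the scatter). Compound 4 `COc1cc(C2=NN(C(C)=O)C(c3ccc(Cl)c(Cl)c3)O2)cc(OC)c1OC` is not yet measured. 3,4-dichlorophenyl in place of 2-(trifluoromethyl)phenyl on a saturated ring carbon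

Both steps into compound 3 were large falls, a number 46 percentage points lower from compound 1 to compound 3 (beyond the scatter) and a number 80.5 percentage points lower from compound 2 to compound 3 (beyond the scatter). Leaving the 2-(trifluoromethyl)phenyl group therefore points to a rise in this assay, though no measured step shows a 3,4-dichlorophenyl group, so its size is uncertain. Compound 4 is expected to give about 30%, with a range of 0% to 60%, an estimated step of a number 41 percentage points higher from compound 3 to compound 4 (beyond the scatter).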

Compound 4, a percentage reported as inhibition, at one concentration (the size of the read-out at that concentration, not a potency): 28.1%
Compound 4: middle estimate off by 1.9 percentage points, on the high side, within the range that was stated.
By their numbers in this assay, from the lowest: compound 3; then compounds 4 and 1 (each within the scatter of the next); then compound 2.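

this assay: at the saturated ring carbon, a chlorinated aryl group avoids the low reading of the 2-(trifluoromethyl)phenyl group, with a number 39.1 percentage points higher from compound 3 to compound 4 (beyond the scatter). Methoxy groups are not needed on this aryl ring for the level of 2,3-dimethoxyphenyl, with a number 6.9 percentage points lower from compound 1 to compound 4 (within the scatter), yet 3,4-dichlorophenyl does not reach the 2,4-dimethoxyphenyl level, with a number 41.4 percentage points lower from compound 2 to compound 4 (beyond the scatter). Nothing available explains these steps.

Open, as far as these compounds go, is how an aryl group bearing an amine or a carboxylic acid would read here, and whether one chlorine alone would hold the level of 3,4-dichlorophenyl.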